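A few compounds are considered here, and "the series" means these few. Any claim that something is new, unique, unknown or untested is made for them only; others in the source may bear on it.

Among the measured compounds shown here, in a functional assay on 786-0 cells (Homo sapiens) for inhibition, read by sulforhodamine B assay, with a stated time of 48 h (a lower number here means a stronger inhibitor of growth, a higher number a weaker inhibitor of growth), only two compounds built on a shared core have been read so far. Compound 1 `CC(C)(C)NCc1c(C(=O)O)nn(-c2ccccc2)c1-c1ccc([N+](=O)[O-])cc1` gives > 634000 nM, which is a limit of the assay and not a number. For the measured compounds named here, compound 2 `CC(C)(C)NCc1c(C(=O)O)nn(-c2ccc(Cl)cc2)c1-c1ccc(Br)cc1` gives 542000 nM, the only actual number available, so it has no exact value to be ranked against. Compound 3 `CC(C)(C)NCc1c(C(=O)O)nn(-c2ccc(Cl)cc2)c1-c1ccc([N+](=O)[O-])cc1` differs from compound 2 in one place: nitro in place of bromo on an aromatic carbon. The change turns 4-bromophenyl into 4-nitrophenyl. Going by the values given here, no measured pair isolates this change, although compound 1 also carries 4-nitrophenyl and reads > 634000 nM, again a limit. No step beyond the usual scatter is therefore expected in this assay, in either direction. The expected change is a 1.1-fold lower number from compound 2 to compound 3 (0.05 log units; within the scatter). For compound 3, the estimated value is 480000 nM, with an expected range of 220000 nM to 700000 nM.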

Compound 3, concentration for 50% growth inhibition: 104000 nM
Estimate against measurement, compound 3: 4.6-fold (0.66 log units) above; the whole stated range lies above it.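

In this assay, among the compounds shown here, nitro in place of bromo on an aromatic carbon, para to a large group, gives a 5.2-fold lower number from compound 2 to compound 3 (0.72 log units; beyond the scatter), so this position responds to the change, and this is the first step here with an exact number at both ends. With 4-nitrophenyl kept in place, chloro in place of hydrogen on an aromatic carbon gives an at least 6.0-fold lower number from compound 1 to compound 3 (0.78 log units; beyond the scatter), which shows that a second site on the shared core also affects the reading. Compound 1 reads > 634000 nM, which is a limit and not a number, so that second step gives only a minimum size: the limit of > 634000 nM in this assay, at which 1 of the 3 values shown sits.

The compounds shown leave open how a nitrile, an amine or a methoxy group would read in place of the nitro group. They also cannot tell what it is about the nitro group that produces the step, or whether the step holds without the chloro.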